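The source may report more compounds than this note shows. Statements on the series, on what has been measured and on what is new or still open speak of the compounds shown alone.

For the measured compounds named here, compound 3 `C=CC(=O)Nc1cccc(NC(=O)CSc2nc(Nc3cccc(F)c3)c3ccccc3n2)c1` stands lowest of the three numbers so far in a functional assay on MDA-MB-231 cells (Homo sapiens) for inhibition, read by MTT assay, with a stated time of 72 h; a lower number here means a stronger inhibitor, a higher number a weaker inhibitor: compound 3 gives 8160 nM, while compound 1 `O=C(CSc1nc(Nc2ccccc2)c2ccccc2n1)Nc1ccc([N+](=O)[O-])cc1` gives 16800 nM and compound 2 `O=C(CSc1nc(Nc2ccccc2)c2ccccc2n1)Nc1ccc(Cl)cc1Cl` gives 19400 nM, both beyond the scatter from compound 3. Compound 4 `C=CC(=O)Nc1cccc(NC(=O)CSc2nc(Nc3ccc(Cl)cc3Cl)c3ccccc3n2)c1` is not yet measured. It differs from compound 3 in one place: 2,4-dichlorophenyl in place of 3-fluorophenyl on a nitrogen on an aromatic ring. Going by the values given here, the only measured step that changes an aryl group on a nitrogen is a 1.2-fold higher number from compound 1 to compound 2 (0.06 log units; within the scatter), where 2,4-dichlorophenyl also enters, though on the amide-type nitrogen rather than on the nitrogen on the aromatic ring. Among the compounds with values here, that step was within the scatter, and no measured pair isolates an aryl swap at the position changed here. Within the data shown here, on this basis the expectation for compound 4 is a step of a 1.2-fold higher number from compound 3 to compound 4 (0.07 log units; within the scatter), not beyond the scatter, with wide uncertainty because the only comparable swap is a 1.2-fold higher number from compound 1 to compound 2 (0.06 log units; within the scatter) at a different place. Compound 4 is therefore estimated at 9500 nM, with a range from 4000 nM to 23000 nM.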

Compound 4, half-maximal inhibitory concentration: 23100 nM
Compound 4: middle estimate off by 2.4-fold (0.39 log units), on the low side, and the stated range ends below it.
By their numbers in this assay, from the lowest: compound 3; then compounds 1, 2 and 4 (each within the scatter of the next).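

In this assay, for the compounds shown here, the aryl group on the nitrogen on the aromatic ring is the first place where a swap moves the number beyond the scatter: 2,4-dichlorophenyl in place of 3-fluorophenyl gives a 2.8-fold higher number from compound 3 to compound 4 (0.45 log units; beyond the scatter) at this place. The same 2,4-dichlorophenyl entering on the amide-type nitrogen gave only a 1.2-fold higher number from compound 1 to compound 2 (0.06 log units; within the scatter) and stayed within the scatter, so its entry does not read the same at the two places, although the groups leaving differ. Nothing measured here speaks to the cause of the larger step.

Open, on these data alone, is whether the higher number follows the two chlorines together or the departure of 3-fluorophenyl. A plain phenyl, a monochlorophenyl or a methoxyphenyl on this nitrogen could separate these two readings.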